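Acyl variation on the sulfonate anilide series

The compounds below may be only part of what the source reports. "The series", "measured", "known", "first", "only" and "open" are said of these compounds alone.

Measured so far in a functional assay on HT-1080 cells (Homo sapiens) for antiproliferative activity, read by sulforhodamine B assay, with a stated time of 48 h; on this read-out higher numbers stand for weaker inhibition and lower numbers for stronger inhibition:
compound 1, `CC(=O)Nc1cccc(S(=O)(=O)Oc2ccccc2C(C)C)c1`, 21000 nM
compound 2, `CCCC(=O)Nc1cccc(S(=O)(=O)Oc2ccccc2C(C)C)c1`, 15000 nM
compound 3, `CC(C)C(=O)Nc1cccc(S(=O)(=O)Oc2ccccc2C(C)C)c1`, 16000 nM

Compound 3 sits second highest of the three numbers; its nearest neighbour is compound 2 and its furthest is compound 1, and all three values lie within the scatter of one another, so no order among them can be read from this assay.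

The next compound is compound 4, `CC(C)c1ccccc1OS(=O)(=O)c1cccc(NC(=O)CCl)c1`. It differs from compound 3 by chloromethyl in place of isopropyl on a carbonyl carbon.

The steps measured so far all sit on the same carbonyl carbon: a 1.4-fold lower number from compound 1 to compound 2 (0.15 log units; within the scatter), a 1.3-fold lower number from compound 1 to compound 3 (0.12 log units; within the scatter) and a 1.1-fold higher number from compound 2 to compound 3 (0.03 log units; within the scatter). Every one of them stays within the scatter, so on this evidence the acyl group has not moved the number. Chloromethyl, however, is unlike any group tried here, and the measured steps give no direct guide to it. The expectation for compound 4 is therefore a step of a 1.6-fold lower number from compound 3 to compound 4 (0.20 log units; within the scatter) in this assay, with a wide range to cover the untested group. Compound 4 is estimated at 10000 nM, between 2500 nM and 30000 nM.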

Compound 4, half-maximal inhibitory concentration: 780 nM
For compound 4 the middle estimate is 13-fold (1.11 log units) above the measured one; the measured number lies below the stated range.
By their numbers in this assay, from the lowest: compound 4; then compounds 2, 3 and 1 (each within the scatter of the next).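

In this assay, the substituent on the carbonyl carbon whose other neighbour is the amide-type nitrogen proves able to shift the number, with a large step on replacing isopropyl by chloromethyl (a 21-fold lower number from compound 3 to compound 4 (1.31 log units; beyond the scatter)), a position that had looked flat across the earlier acyl groups. The same holds for chloro in place of ethyl on the saturated chain carbon bound to the carbonyl carbon (a 19-fold lower number from compound 2 to compound 4 (1.28 log units; beyond the scatter)), and for the closest comparison, chloro in place of hydrogen on that carbon (a 27-fold lower number from compound 1 to compound 4 (1.43 log units; beyond the scatter)), so a single chlorine on the chain carbon accounts for a change that neither lengthening nor branching the acyl chain produced. No measurement among the data bears on why this change has so large an effect.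

The compounds shown leave open whether the gain is specific to chlorine or would also appear with bromomethyl, fluoromethyl or methoxymethyl on the carbonyl carbon. They also leave open whether a longer chain carrying the chloro, such as chloroethyl, would keep the gain, and whether it survives replacing the isopropyl on the far side of the shared core.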